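The source may report more compounds than this note shows. Statements on the series, on what has been measured and on what is new or still open speak of the compounds shown alone.

Compound 1 `COc1ccc(NC(=O)[C@H]2CCCN2C(=O)C2(c3cccc(Cl)c3)CCCC2)nc1` has the higher of the two numbers recorded in an assay on isolated protein for inhibition of histone acetyltransferase p300 (Homo sapiens), with a stated time of 60 min; a higher number here means a weaker inhibitor, a lower number a stronger inhibitor: compound 1 gives 2 nM, while compound 2 `COc1ccc(C2(C(=O)N3CCC[C@@H]3C(=O)Nc3ccc4[nH]ncc4n3)CCC2)cc1` gives 0.251 nM. Compound 3 `O=C(Nc1ccc2[nH]nnc2c1)[C@H]1CCCN1C(=O)C1(c2cccc(Cl)c2)CCCC1` has not yet been measured in this assay. Set against compound 1, its change is a group of 9 heavy atoms (6 carbon, 3 nitrogen; one five-membered aromatic ring with 3 hetero atoms, one six-membered aromatic ring of carbon only) in place of a group of 8 heavy atoms (6 carbon, 1 nitrogen, 1 oxygen; one six-membered aromatic ring with 1 hetero atom), on an amide-type nitrogen. For the measured compounds named here, with no measured pair isolating this change, any forecast rests on the two values above, and an improvement is expected from compound 1 to compound 3 of about a 2.0-fold lower number from compound 1 to compound 3 (0.30 log units; within the scatter) in this assay. Compound 3 is therefore estimated at 1 nM, within a range from 0.3 nM to 4 nM.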

Compound 3, half-maximal inhibitory concentration in the histone acetyltransferase p300 assay: 20 nM
Compound 3: middle estimate off by 20-fold (1.30 log units), on the low side; the whole stated range lies below it.
By their numbers in the histone acetyltransferase p300 assay, from the lowest: compound 2; then compound 1; then compound 3.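

This position is sensitive to the group it carries: in the histone acetyltransferase p300 assay, replacing 5-methoxypyridin-2-yl on the amide-type nitrogen with the two-ring group bearing a hydrogen-bond donor gives a 10-fold higher number from compound 1 to compound 3 (1.00 log units; beyond the scatter). The same change also shifts a physicochemical assay for lipophilicity, at pH 7.4; on this read-out higher numbers stand for higher lipophilicity and lower numbers for lower lipophilicity: the measured distribution coefficient of compound 1, 6.8, and of compound 3, 5.2, a number 1.60 log units lower (beyond the scatter) In the physicochemical assay compound 1 gives 6.8, and compound 3 gives 5.2.

This single pair cannot separate the lower lipophilicity from the added hydrogen-bond donor or the change of ring as the source of the weaker inhibition. Going by these compounds, how a plain phenyl, or a pyridine carrying an amine instead of the methoxy, would behave on this nitrogen remains open.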